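The source may report more compounds than this note shows. Statements on the series, on what has been measured and on what is new or still open speak of the compounds shown alone.

Values in a functional assay on HL-60 cells (Homo sapiens) for inhibition, read by CCK-8 assay, with a stated time of 48 h; on this read-out lower numbers stand for stronger inhibition and higher numbers for weaker inhibition:
compound 1 `O=C(NCCNS(=O)(=O)c1ccc(-c2ccccc2OCc2cccc(O)c2)s1)Nc1cc(C(F)(F)F)cc(C(F)(F)F)c1`: 4000 nM
compound 2 `Cc1ccc(-c2ccsc2S(=O)(=O)NCCNC(=O)Nc2ccc([N+](=O)[O-])cc2)c(Oc2ccc(O)c(O)c2)c1`: 3900 nM

Compound 1 stands level with compound 2. Their two values lie within the scatter of each other, so the pair cannot be ranked.

The next compound to be read is compound 3 `O=C(NCCNS(=O)(=O)c1ccc(-c2ccccc2Oc2ccc(O)c(O)c2)s1)Nc1cc(C(F)(F)F)cc(C(F)(F)F)c1`, which keeps the core of compound 1 and alters one group: 3,4-dihydroxyphenyl in place of 3-hydroxybenzyl on an oxygen on an aromatic ring. In words, this is 3,4-dihydroxyphenyl in place of 3-hydroxybenzyl on an oxygen on an aromatic ring.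

Among the measured compounds shown here, no measured pair isolates this change. Compound 2 already carries 3,4-dihydroxyphenyl on such an oxygen and gives 3900 nM, but it also differs from compound 1 elsewhere, so it offers only indirect guidance. A small move toward stronger inhibition in this assay is expected, not clearly beyond the scatter. The expected step is a 1.6-fold lower number from compound 1 to compound 3 (0.20 log units; within the scatter). For compound 3 the estimated value is 2500 nM, with an expected range from 800 nM to 6500 nM.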

Compound 3, half-maximal inhibitory concentration: 10500 nM
Estimate against measurement, compound 3: 4.2-fold (0.62 log units) below; the measured number lies above the stated range.
By their numbers in this assay, from the lowest: compounds 2 and 1 (each within the scatter of the next); then compound 3.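

In this assay, among the compounds shown here, 3,4-dihydroxyphenyl in place of 3-hydroxybenzyl on an oxygen on an aromatic ring gives a 2.6-fold higher number from compound 1 to compound 3 (0.42 log units; beyond the scatter) and is the first change read in one place alone, showing that this position responds to the group it carries and that, of these two groups, 3-hydroxybenzyl goes with the lower number. The step is modest, and the change alters the link between the oxygen and the ring together with the hydroxyl pattern on the ring, so this pair cannot assign the step to either feature. Nothing measured here accounts for the rise in the number.

Still open, going by these compounds, is which of the two features carries the step: 3-hydroxyphenyl or 3,4-dihydroxybenzyl on the same oxygen would separate them. Also open, on these data alone, is whether the position tolerates groups of another kind, such as an amine or a carboxylic acid on the ring, or a longer chain between the oxygen and the ring, and whether the step holds on the core of compound 2.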